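From trifluoromethyl to cyano on an aromatic carbon

A few compounds are considered here, and "the series" means these few. Any claim that something is new, unique, unknown or untested is made for them only; others in the source may bear on it.

Compound 1 `C=CS(=O)(=O)N1CCN(c2ccn3ncc(-c4ccccc4)c3n2)CC1` gives 19500 nM
Compound 2 `C=CS(=O)(=O)N1CCN(c2ncnc3sc(-c4ccc(C(F)(F)F)cc4)cc23)CC1` gives 7080 nM

In a functional assay on MDA-MB-436 cells (Homo sapiens) for antiproliferative activity, read by MTT assay, with a stated time of 48 h (on this read-out higher numbers stand for weaker inhibition and lower numbers for stronger inhibition), only these two compounds have been measured so far. Compound 2 holds the lower number (at 7080 nM) and compound 1 holds the higher number (at 19500 nM), with a gap beyond the usual scatter. The two differ in more than one place, so that gap cannot be tied to any single group.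

The next compound is compound 3 `C=CS(=O)(=O)N1CCN(c2ncnc3sc(-c4ccc(C#N)cc4)cc23)CC1` which departs from compound 2 at one place only. The change is cyano in place of trifluoromethyl on an aromatic carbon that is, cyano in place of trifluoromethyl on an aromatic carbon, para to a large group. Within the data shown here, no measured pair shows what this exchange does, which leaves compound 2 (at 7080 nM) as the only anchor for the expectation. In this assay a small step towards weaker inhibition is therefore expected (a 1.3-fold higher number from compound 2 to compound 3 (0.10 log units; within the scatter)) and it may well stay within the scatter. The value expected for compound 3 is 9000 nM with an estimated range from 3500 nM to 22000 nM in this measurement.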

Compound 3, half-maximal inhibitory concentration: 9170 nM
Compound 3: middle estimate off by 1.0-fold (0.01 log units), on the low side; measured number inside the range.
By their numbers in this assay, from the lowest: compounds 2 and 3 (each within the scatter of the next); then compound 1.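

In this assay, among these compounds, the exchange of trifluoromethyl for cyano, on an aromatic carbon para to a large group, gives a 1.3-fold higher number from compound 2 to compound 3 (0.11 log units; within the scatter) and is the first comparison that can be tied to a single place. At this position, then, a group with a triple bond and a hydrogen-bond acceptor can stand in for one with neither, and fewer heavy atoms, while the two compounds remain within the scatter of each other on this read-out. Nothing measured here accounts for this result.

The compounds shown leave open whether the same holds for quite different groups at this place, such as an amine, a carboxylic acid, a methoxy group or a longer alkyl chain, or for plain hydrogen. As this is a single pair on a single core, they also leave open whether the exchange from 4-(trifluoromethyl)phenyl to 4-cyanophenyl would give a similar result on the core of compound 1.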